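Notes on the cyclobutyl step from compound 1

This account rests on a few compounds, and the source may have more. Where it says the series, first, only, none or still open, it means among the compounds named here.

Values measured so far in an ADME assay on microsomes (Homo sapiens) for metabolic stability (a higher number here means that the compound lasts longer, a lower number that the compound disappears faster), are as follows.
- Compound 1 `O=C(C1CCCC1)N1N=CCC1c1ccccc1` gives 1.13 h
- Compound 2 `C[C@@H]1C=NN(C(=O)C(C)(C)C)[C@@H]1c1ccccc1` gives 0.45 h
- Compound 3 `CC(C)(C)C(=O)N1N=CCC1c1cocn1` gives > 1.5 h

Compound 1 at 1.13 h holds the higher of the two plain numbers, and compound 2 at 0.45 h lies lower by more than the scatter. The entry for compound 3 is a limit of the assay and not a number.

Compound 4 `O=C(C1CCC1)N1N=CCC1c1ccccc1` keeps the core of compound 1 and carries cyclobutyl in place of cyclopentyl on a carbonyl carbon in the same place. Among the compounds with values here, no two measured compounds differ in one place only, so the series offers no direct guide to this change. With compound 1 at 1.13 h as the anchor, only a slight lengthening of the half-life is expected, within the scatter. The expected change is a 1.2-fold higher number from compound 1 to compound 4 (0.06 log units; within the scatter) in this assay on this reading. The estimate for compound 4 is 1.3 h, expected to fall from 0.7 h to 2.2 h on measurement. A report as a limit only remains possible for compound 4.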

Compound 4, half-life: 1.38 h
The estimate for compound 4 lay 1.1-fold (0.03 log units) below the measured number; measured number inside the range.
By their numbers in this assay, from the lowest: compound 2; then compounds 1 and 4 (each within the scatter of the next). At a limit, above all of these: compound 3.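

In this assay, cyclobutyl in place of cyclopentyl on a carbonyl carbon leaves the half-life without a readable change: a 1.2-fold higher number from compound 1 to compound 4 (0.09 log units; within the scatter). Within the data shown here, this is the only one-place step so far, and it shows that at this position, whose other neighbours are an amide-type nitrogen in a ring, the carbon-only ring can lose one carbon without the result leaving the scatter. The read-out also has an upper end that matters for any further steps here: the limit of > 1.5 h in this assay, at which 1 of the 4 values shown sits.

On these data alone, whether this position accepts anything other than a carbon-only ring stays open, for instance a ring carrying an amine or a carboxylic acid. Compound 2 and compound 3 each differ from compound 1 in more than one place, so steps to them cannot be read.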